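A few compounds are considered here, and "the series" means these few. Any claim that something is new, unique, unknown or untested is made for them only; others in the source may bear on it.

Working notes on the series. Going by the values given here, in a functional assay on PC-3 cells (Homo sapiens) for inhibition, read by MTT assay, with a stated time of 48 h (a lower number here means a stronger inhibitor, a higher number a weaker inhibitor), compound 2 `CCN1CCN(C(=S)SCCCOc2ccc3c(=O)c(-c4ccc(OC)cc4)coc3c2)CC1` gives 7080 nM, the middle of the three numbers so far. Compound 3 `COc1ccc(-c2coc3cc(OCCCSC(=S)N4CCN(C(=O)OC(C)(C)C)CC4)ccc3c2=O)cc1` gives 1970 nM, and compound 1 `COc1ccc(-c2coc3cc(OCCCBr)ccc3c2=O)cc1` gives 62600 nM. Compound 4 `COc1ccc(-c2coc3cc(OCCCCCBr)ccc3c2=O)cc1` differs from compound 2 by a group of 3 heavy atoms (2 carbon, 1 bromine; no ring) in place of a group of 11 heavy atoms (7 carbon, 2 nitrogen, 2 sulfur; one six-membered non-aromatic ring with 2 hetero atoms), on a saturated chain carbon, three bonds along the chain from an oxygen on an aromatic ring, so it ends in a bromine, as compound 1 does, and has lost the six-membered non-aromatic ring. The closest measured step is an 8.8-fold lower number from compound 1 to compound 2 (0.95 log units; beyond the scatter), a modest one in which that same group replaced a bromine. The other measured step, a 3.6-fold lower number from compound 2 to compound 3 (0.56 log units; beyond the scatter), is also modest, but it changes only a substituent on a ring that compound 4 lacks, so it bears on this change only weakly. Among the compounds with values here, no measured step shows what 2-bromoethyl does in place of bromine. A modest step to a higher number is therefore expected in this assay, roughly reversing the first step. The expected step is a 6.4-fold higher number from compound 2 to compound 4 (0.80 log units; beyond the scatter). For compound 4 the estimated value is 45000 nM, with an expected range of 15000 nM to 130000 nM.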

Compound 4, half-maximal inhibitory concentration: 44800 nM
Beside the measured number, compound 4's estimate is 1.0-fold (0.00 log units) above it; the measured number falls inside the stated range.
By their numbers in this assay, from the lowest: compound 3; then compound 2; then compounds 4 and 1 (each within the scatter of the next).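

In this assay, 2-bromoethyl in place of bromo at this saturated chain carbon gives a 1.4-fold lower number from compound 1 to compound 4 (0.15 log units; within the scatter), so this change to the bromine-ended chain does not separate compound 1 from compound 4. The larger gap appears with the group of 11 heavy atoms: a 6.3-fold higher number from compound 2 to compound 4 (0.80 log units; beyond the scatter), a step that also changes chain length, yet of a size close to an 8.8-fold lower number from compound 1 to compound 2 (0.95 log units; beyond the scatter), so among these compounds the two bromine-ended members stand apart from compound 2 whichever chain they carry. No evidence on the cause of this difference is at hand.

As far as these compounds go, it remains open whether a longer chain carrying the ring-bearing group of compound 2 would keep the number of compound 2. Equally open, from the compounds shown here alone, is how a simple amine or a carboxylic acid at the chain end would compare with bromine.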